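The source may hold more compounds than are shown below. What is called first, only, known or untested is meant among the compounds shown, and "the series" means these compounds.

Measured compounds:
Compound 1, `Cc1oncc1NS(=O)(=O)c1ccc(F)c2ncc(I)cc12`, gives 2100 nM in an assay for inhibition of methylcytosine dioxygenase TET2 (Homo sapiens), read by mass spectrometry, with stated times of 30 min and 1 h; a lower number here means a stronger inhibitor, a higher number a weaker inhibitor.
Compound 2, `NS(=O)(=O)c1ccc(F)c2ncc(I)cc12`, gives 86600 nM in this assay.

Compound 1 stands lowest of the two numbers; its nearest neighbour is compound 2, reached by a 41-fold higher number from compound 1 to compound 2 (1.62 log units; beyond the scatter), a large step beyond the scatter. Compound 3, `CNS(=O)(=O)c1ccc(F)c2ncc(I)cc12`, differs from compound 1 by methyl in place of 5-methyl-1,2-oxazol-4-yl on a sulfonamide nitrogen. Among the compounds with values here, the only measured step that bears on this position is a 41-fold higher number from compound 1 to compound 2 (1.62 log units; beyond the scatter), in which the group on the sulfonamide nitrogen was replaced by hydrogen. The change to compound 3 replaces that group with methyl rather than removing it outright, so a loss is expected, but one expected to be smaller than that step. The expected step for compound 3 is a 9.5-fold higher number from compound 1 to compound 3 (0.98 log units; beyond the scatter), toward a higher number in this assay. Compound 3 is therefore estimated at 20000 nM, with a range from 5000 nM to 80000 nM.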

Compound 3, half-maximal inhibitory concentration: > 200000 nM
Compound 3: no number, only a limit; the forecaster's own chance of this, stated with the estimate: 5%; middle value at least 10-fold (1.00 log units) away from the limit.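

In this assay, compound 3 gives > 200000 nM, and this value is a limit of the assay, not a number: the limit of > 200000 nM in this assay, at which 1 of the 3 values shown sits. Exchanging 5-methyl-1,2-oxazol-4-yl for methyl gives an at least 95-fold higher number from compound 1 to compound 3 (1.97 log units; beyond the scatter), so a small group on the sulfonamide nitrogen does not keep part of what the 5-methyl-1,2-oxazol-4-yl group gives. Methyl in place of hydrogen gives an at least 2.3-fold higher number from compound 2 to compound 3 (0.36 log units; beyond the scatter), so merely carrying a group on this nitrogen does not lower the number, and methyl goes against any reading that every group does better than hydrogen.

The three compounds leave open whether the ring or its methyl matters, as a 1,2-oxazol-4-yl group without the methyl or a phenyl ring could tell. They also leave open how a longer chain, such as propyl, or a chain ending in an amine would behave on this nitrogen.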